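The source may hold more compounds than are shown below. What is called first, only, known or untested is meant among the compounds shown, and "the series" means these compounds.

Measured so far:
- compound 1, `C/C=C/C(=O)N(Cc1ccc(OC)c([N+](=O)[O-])c1)c1cc(OC)c(OC)c(OC)c1`, in a functional assay on KYSE-450 cells (Homo sapiens) for inhibition, read by MTT assay, with a stated time of 48 h (on this read-out lower numbers stand for stronger inhibition and higher numbers for weaker inhibition), compound 1 gives 510 nM
- compound 2, `COc1ccc(CN(C(C)=O)c2cc(OC)c(OC)c(OC)c2)cc1O`, in this assay compound 2 gives 160 nM

Both compounds share the same core and differ in more than one place, so their two values can only be set side by side: compound 2 has the lower number of the two, and the gap to compound 1 lies beyond the usual scatter.

Compound 3, `COc1ccc(CN(C(=O)C(C)C)c2cc(OC)c(OC)c(OC)c2)cc1O`, has not yet been measured. It differs from compound 2 in one place only: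

isopropyl in place of methyl on a carbonyl carbon

For the measured compounds named here, no measured pair shows this kind of change, so there is nothing to lean on except the change itself, which adds carbon without touching any donor, acceptor or charge. The expectation is a step of a 1.4-fold higher number from compound 2 to compound 3 (0.14 log units; within the scatter) that stays within the scatter, perhaps leaning towards a slightly higher number. Compound 3 is therefore estimated at 220 nM, with a range from 80 nM to 650 nM.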

Compound 3, half-maximal inhibitory concentration: 390 nM
The estimate for compound 3 lay 1.8-fold (0.25 log units) below the measured number; the measured number falls inside the stated range.
By their numbers in this assay, from the lowest: compound 2; then compounds 3 and 1 (each within the scatter of the next).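

For the compounds shown here, compound 2 and compound 3 give the first direct reading of the group on this carbonyl carbon, whose other neighbour is the amide-type nitrogen. In this assay, isopropyl in place of methyl gives a 2.4-fold higher number from compound 2 to compound 3 (0.39 log units; beyond the scatter), so adding carbon here weakens inhibition. The step is modest but beyond the usual scatter, which shows that this position is not indifferent to the group it carries, although nothing available here explains the rise.

Methyl and isopropyl are only two points, so they cannot show whether the number climbs steadily as carbon is added at this position. As far as these compounds go, whether an ethyl group would fall between them, and how a cyclopropyl ring, a phenyl ring or an amine on the same carbonyl carbon would behave, remains open.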